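A few compounds are considered here, and "the series" means these few. Any claim that something is new, unique, unknown or untested is made for them only; others in the source may bear on it.

Compound 1 `O=C(Nc1cccc(-n2cc(-c3ccncc3)c(-c3cc(O)cc(Cl)c3)n2)c1)Nc1ccc(Cl)c(C(F)(F)F)c1` is the starting point. In a functional assay on MOLT-4 cells (Homo sapiens) for inhibition, read by sulforhodamine B assay, with a stated time of 48 h, tested at 1 uM (on this read-out higher numbers stand for a weaker effect at the one concentration tested and lower numbers for a stronger effect), compound 1 gives 52%. Compound 2 `COc1cc(Cl)cc(-c2nn(-c3cccc(NC(=O)Nc4ccc(Cl)c(C(F)(F)F)c4)c3)cc2-c2ccncc2)c1` differs from it only by a methyl in place of hydrogen on an oxygen on an aromatic ring, and in this assay compound 2 gives 58%. The step of a number 6 percentage points higher from compound 1 to compound 2 (within the scatter) is small and within the usual scatter, so these two numbers should be read as alike. Among the two numbers measured so far compound 2 stands highest, with compound 1 nearest and within the scatter of it.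

Compound 3 `COc1cc(Cl)cc(-c2nn(-c3cccc(NC(=O)c4cccc(C(F)(F)F)c4)c3)cc2-c2ccncc2)c1` is not yet measured. It differs from compound 2 in one place: 3-(trifluoromethyl)phenyl in place of (4-chloro-3-(trifluoromethyl)phenyl)amino on a carbonyl carbon. Going by the values given here, the only measured step, from compound 1 to compound 2, concerns a methyl on an oxygen elsewhere in the molecule and says nothing about a change at the carbonyl carbon, so no measured step bears on this change. Without such guidance, the number for compound 3 is expected to stay near the number for compound 2, and the step of a number 2 percentage points higher from compound 2 to compound 3 (within the scatter) is expected to remain within the scatter. Compound 3 is therefore estimated at 60%, with a range from 35% to 85%.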

Compound 3, a percentage reported as activity, at one concentration (the size of the read-out at that concentration, not a potency): 72%
Compound 3: middle estimate off by 12 percentage points, on the low side, within the range that was stated.
By their numbers in this assay, from the lowest: compounds 1 and 2 (each within the scatter of the next); then compound 3.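

Where the methyl on the oxygen gave only a number 6 percentage points higher from compound 1 to compound 2 (within the scatter) in this assay, the change on the carbonyl carbon gives a number 14 percentage points higher from compound 2 to compound 3 (beyond the scatter) and so moves the read-out by more than the scatter. Higher numbers here stand for a weaker effect, so 3-(trifluoromethyl)phenyl in place of (4-chloro-3-(trifluoromethyl)phenyl)amino loses a modest part of the effect at the one concentration tested, and this position responds to change in a way the oxygen did not. The step alters two things at once, as the leaving group holds both a chlorine and a nitrogen with a hydrogen-bond donor while the entering group has neither, and nothing measured here explains the loss.

The compounds shown do not separate these two features, so it remains open whether 4-chloro-3-(trifluoromethyl)phenyl on the carbonyl carbon, with the chlorine kept and the nitrogen gone, would restore the effect. On these data alone, it is also open how this position would respond to a quite different group on the carbonyl carbon, such as a morpholine ring or a longer carbon chain.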